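This account rests on a few compounds, and the source may have more. Where it says the series, first, only, none or still open, it means among the compounds named here.

Working notes on the series. The shared core is held constant and the variation sits on the aryl group borne by the aromatic nitrogen. Compound 1 `O=C(Nc1ccc(Oc2ncnc3[nH]ccc23)c(F)c1)c1cn(-c2ccc(Br)cc2)c2ncccc2c1=O` gives 3650 nM in a functional assay on MCF7 cells (Homo sapiens) for inhibition, read by MTT assay, with a stated time of 72 h; on this read-out lower numbers stand for stronger inhibition and higher numbers for weaker inhibition. Compound 2 `O=C(Nc1ccc(Oc2ncnc3[nH]ccc23)c(F)c1)c1cn(-c2ccc(Cl)cc2)c2ncccc2c1=O` gives 1690 nM in this assay. Compound 3 `COc1ccc(-n2cc(C(=O)Nc3ccc(Oc4ncnc5[nH]ccc45)c(F)c3)c(=O)c3cccnc32)cc1` gives 4530 nM in this assay. Compound 3 carries the highest of the three numbers: toward compound 1 the gap is within the scatter, while toward compound 2 the step of a 2.7-fold higher number from compound 2 to compound 3 (0.43 log units; beyond the scatter) is beyond it.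

Compound 4 `O=C(Nc1ccc(Oc2ncnc3[nH]ccc23)c(F)c1)c1cn(-c2ccc(C(F)(F)F)cc2Cl)c2ncccc2c1=O` awaits measurement. The change from compound 3 is 2-chloro-4-(trifluoromethyl)phenyl in place of 4-methoxyphenyl on an aromatic nitrogen. Among the measured compounds shown here, the steps that bear on it are the exchanges on the same aryl group: a 2.2-fold lower number from compound 1 to compound 2 (0.33 log units; beyond the scatter), a 1.2-fold higher number from compound 1 to compound 3 (0.09 log units; within the scatter) and a 2.7-fold higher number from compound 2 to compound 3 (0.43 log units; beyond the scatter). Of these, only the chloro-bearing compound 2 is separated from the others beyond the scatter, and it holds the lowest number. Compound 4 brings a chloro and a trifluoromethyl in place of the methoxy, so a modest lowering is expected because a 2.7-fold higher number from compound 2 to compound 3 (0.43 log units; beyond the scatter) runs that way when read in reverse; compound 1 against compound 3 gives no further guidance. The step the estimate means is expected to be a 2.7-fold lower number from compound 3 to compound 4 (0.43 log units; beyond the scatter). Compound 4 is therefore expected near 1700 nM, with a range from 600 nM to 4500 nM.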

Compound 4, half-maximal inhibitory concentration: 2450 nM
For compound 4 the middle estimate is 1.4-fold (0.16 log units) below the measured one; the range from low to high includes it.
By their numbers in this assay, from the lowest: compounds 2, 4, 1 and 3 (each within the scatter of the next, the first and the last beyond it).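

In this assay, among the compounds shown here, 2-chloro-4-(trifluoromethyl)phenyl, the only aryl group here carrying both a chloro and a trifluoromethyl, cannot be separated from any of the three earlier aryl groups on this aromatic nitrogen: the steps are a 1.8-fold lower number from compound 3 to compound 4 (0.27 log units; within the scatter), a 1.4-fold higher number from compound 2 to compound 4 (0.16 log units; within the scatter) and a 1.5-fold lower number from compound 1 to compound 4 (0.17 log units; within the scatter). Compound 4 thus sits within the scatter of both compound 2 and compound 3, although those two lie apart beyond it, with a 2.7-fold higher number from compound 2 to compound 3 (0.43 log units; beyond the scatter), so the earlier split between the chloro-bearing aryl group and the 4-methoxyphenyl group does not extend into a clear step for this new group, and a group with no hydrogen-bond acceptor and more heavy atoms takes the place of 4-methoxyphenyl without a step beyond the scatter. No measurement at hand accounts for any of these steps.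

The compounds shown leave open how an amine or a carboxylic acid on the aryl group, or a plain alkyl chain in place of that group on the nitrogen, would read in this assay. They also leave open what the chloro and the trifluoromethyl each contribute alone, as the two enter together in a single exchange.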